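Amide nitrogen substituent: ring to chain in the series

The source may report more compounds than this note shows. Statements on the series, on what has been measured and on what is new or still open speak of the compounds shown alone.

Three compounds of the shared core carry a fluorophenyl on the core and an aryl amide. Compound 1 `Cc1c(C(=O)Nc2cccc(F)c2)cnn1-c1ccc(F)cc1` gives 3000 nM in a functional assay with Homo sapiens as the target; on this read-out lower numbers stand for stronger inhibition and higher numbers for weaker inhibition. Compound 2 `Cc1cccc(NC(=O)c2cnn(-c3ccc(F)cc3)c2C)c1` gives 5700 nM in this assay, the highest of the three numbers; the step of a 1.9-fold higher number from compound 1 to compound 2 (0.28 log units; within the scatter) lies within the scatter, whereas the step of a 3.4-fold lower number from compound 2 to compound 3 (0.53 log units; beyond the scatter) lies beyond it. Compound 3 `Cc1c(C(=O)Nc2cccc(C(F)(F)F)c2)cnn1-c1ccc(F)cc1` gives 1700 nM in this assay, and the step of a 1.8-fold lower number from compound 1 to compound 3 (0.25 log units; within the scatter) is again within the scatter.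

Compound 4 `CCCCC(CC)NC(=O)c1cnn(-c2ccc(F)cc2)c1C` differs from compound 2 in one place: 1-ethylpentyl in place of 3-methylphenyl on an amide-type nitrogen. Every measured step in this set swaps one substituent on the aromatic ring of the amide for another; none replaces that ring by an open chain. Going by the values given here, no measured step therefore bears on this change, and the expectation rests on the structural change alone, with a wide range. For compound 4 the estimate in this assay is 12000 nM, with a range from 2500 nM to 60000 nM. The expected step is a 2.1-fold higher number from compound 2 to compound 4 (0.32 log units; beyond the scatter), toward a higher number, but the uncertainty is large.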

Compound 4, half-maximal inhibitory concentration: 580 nM
The estimate for compound 4 lay 21-fold (1.32 log units) above the measured number; the whole stated range lies above it.
By their numbers in this assay, from the lowest: compound 4; then compounds 3, 1 and 2 (each within the scatter of the next, the first and the last beyond it).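

Replacing the aromatic ring on the amide-type nitrogen by 1-ethylpentyl gives a 9.8-fold lower number from compound 2 to compound 4 (0.99 log units; beyond the scatter) in this assay, and the same chain gives a 5.2-fold lower number from compound 1 to compound 4 (0.71 log units; beyond the scatter) when it replaces 3-fluorophenyl. This position therefore does not require an aromatic ring, and in these two pairs the open chain gives the lower number. Changing the substituent on the ring had shown only smaller differences, the largest being a 3.4-fold lower number from compound 2 to compound 3 (0.53 log units; beyond the scatter), so the ring-to-chain change opens a direction that those compounds did not reveal. Nothing available here explains why the chain lowers the number.

The compounds shown do not separate the effect of the branch in 1-ethylpentyl from that of an open chain as such; an unbranched heptyl chain or a cyclohexyl group on the same nitrogen would address this. From the compounds shown here alone, how the read-out responds to a longer chain, or to an amine or a carboxylic acid carried on the chain, also remains open.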